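A few compounds are considered here, and "the series" means these few. Any claim that something is new, unique, unknown or untested is made for them only; others in the source may bear on it.

In a functional assay on cells (Neutrophil, Homo sapiens) for inhibition, read by transwell migration (on this read-out higher numbers stand for weaker inhibition and lower numbers for stronger inhibition), compound 1 `CCOC(=O)c1c(NCCN(C)C)n(-c2ccccc2)c(=S)n(-c2ccccc2)c1=O` gives 0.1 nM, compound 2 `CCOC(=O)c1c(NCCCN(C)C)n(-c2ccccc2)c(=S)n(-c2ccccc2)c1=O` gives 3.89 nM and compound 3 `CCOC(=O)c1c(NCCN2CCCCC2)n(-c2ccccc2)c(=S)n(-c2ccccc2)c1=O` gives 85.4 nM, the highest of the three numbers. Compound 4 `CCOC(=O)c1c(NCCC2CCCN2C)n(-c2ccccc2)c(=S)n(-c2ccccc2)c1=O` differs from compound 3 on a saturated chain carbon, two bonds along the chain from a nitrogen on an aromatic ring: 1-methylpyrrolidin-2-yl in place of piperidin-1-yl on a saturated chain carbon, two bonds along the chain from a nitrogen on an aromatic ring. For the measured compounds named here, no measured step makes this exact swap, but three bear on that chain carbon: a 22-fold higher number from compound 2 to compound 3 (1.34 log units; beyond the scatter), an 850-fold higher number from compound 1 to compound 3 (2.93 log units; beyond the scatter) and a 39-fold higher number from compound 1 to compound 2 (1.59 log units; beyond the scatter). All three are large, so a sizeable step is expected here too, towards a lower number since compound 3 stands highest. The expected change is a 3.4-fold lower number from compound 3 to compound 4 (0.53 log units; beyond the scatter). For compound 4 the estimated value is 25 nM, with an expected range from 3 nM to 200 nM.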

Compound 4, half-maximal inhibitory concentration: 1.61 nM
Compound 4: the middle estimate sits 16-fold (1.19 log units) above what was measured; the whole stated range lies above it.
By their numbers in this assay, from the lowest: compound 1; then compound 4; then compound 2; then compound 3.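

In this assay the swap from piperidin-1-yl to 1-methylpyrrolidin-2-yl gives a 53-fold lower number from compound 3 to compound 4 (1.72 log units; beyond the scatter) with the same atoms joined differently, so at this chain carbon the arrangement of the amine-bearing ring counts, not its atoms alone. A ring here is thus not tied to a high number: replacing (dimethylamino)methyl gives a 2.4-fold lower number from compound 2 to compound 4 (0.38 log units; beyond the scatter) and replacing dimethylamino gives a 16-fold higher number from compound 1 to compound 4 (1.21 log units; beyond the scatter), leaving compound 1 lowest. Nothing measured here explains these differences. On these data alone, whether pyrrolidin-1-yl or 1-methylpiperidin-2-yl at this place would side with compound 3 or compound 4 stays open.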